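Chalcone-bearing series: estimating compound 4 in the cell assay

A few compounds are considered here, and "the series" means these few. Any claim that something is new, unique, unknown or untested is made for them only; others in the source may bear on it.

Measured so far:
- compound 1 `COc1ccc(C(=O)/C=C/c2cc(-c3cc(OC)c(OC)c(OC)c3)n3nc(-c4ccccc4)cc3n2)cc1OC`: 81700 nM
- compound 2 `COc1ccc(-c2cc(/C=C/C(=O)c3ccc(OC)c(OC)c3)nc3cc(-c4ccccc4)nn23)cc1`: 48500 nM
- compound 3 `COc1ccc(-c2cc(C(=O)/C=C/c3ccccc3)nc3cc(-c4ccccc4)nn23)cc1OC`: 64100 nM

All three values come from an ADME assay on HEK293 cells (Homo sapiens) for antiproliferative activity, read by MTT assay, with a stated time of 24 h; a lower number here means a stronger inhibitor, a higher number a weaker inhibitor. Compound 1 gives the highest of the three numbers, yet its gaps to the others fall within the scatter: the step of a 1.7-fold lower number from compound 1 to compound 2 (0.23 log units; within the scatter) is small, and the values of compound 1 and compound 3 are likewise indistinguishable on this footing. Nothing among these three can be ranked.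

Compound 4 `COc1cc(-c2cc(/C=C/C(=O)c3ccc(Cl)cc3)nc3cc(-c4ccccc4)nn23)cc(OC)c1OC` is not yet measured. Relative to compound 1 the change is 4-chlorophenyl in place of 3,4-dimethoxyphenyl on a carbonyl carbon. For the measured compounds named here, no measured step touches the carbonyl-bound ring, so none bears directly on this change. Going by the values given here, the one step on record, from compound 1 to compound 2, removes methoxy groups from the other aryl ring and stays within the scatter; compound 3, with an unsubstituted phenyl at the chain end, sits in the same narrow band. Taken together these give no reason to expect the new compound to move beyond the scatter in this assay, in either direction.

Compound 4 is therefore expected at about 70000 nM, within 35000 nM to 140000 nM, which corresponds to an expected step of a 1.2-fold lower number from compound 1 to compound 4 (0.07 log units; within the scatter).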

Compound 4, half-maximal inhibitory concentration: >= 100000 nM
Compound 4 ended at the assay's limit; the forecaster's own chance of this, stated with the estimate: 20%; middle value at least 1.4-fold (0.15 log units) from the limit.
By their numbers in this assay, from the lowest: compounds 2, 3 and 1 (each within the scatter of the next). At a limit, above all of these: compound 4.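

Carbonyl-bound ring: in this assay, the only step on record at this position, 4-chlorophenyl in place of 3,4-dimethoxyphenyl on a carbonyl carbon, is an at least 1.2-fold higher number from compound 1 to compound 4 (0.08 log units; that floor lies within the scatter). For compound 4, the reading >= 100000 nM is a limit of the assay, not a number. This position now has its first reading, and the change, which takes out both hydrogen-bond acceptors of the leaving ring, shows no gain in inhibition, while the true size of the step stays unknown because only its floor can be read from the one limit value among the compounds shown: the limit of >= 100000 nM in this assay, at which 1 of the 4 values shown sits.

For the compounds shown here, open: whether this step is a real loss or stays within the scatter, and whether the chlorine or the absence of the two methoxy groups accounts for the reading, since the single change alters both at once. Also open, from the compounds shown here alone, is whether a basic or acidic group on the same carbonyl-bound ring, such as 4-aminophenyl or 4-carboxyphenyl, would move the number away from this narrow high band.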